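The compounds below may be only part of what the source reports. "The series", "measured", "known", "first", "only" and "open" are said of these compounds alone.

Three compounds have been measured in a functional assay on HEK293 cells for agonist activity at growth hormone secretagogue receptor type 1 (Homo sapiens), read by HTRF and inositol phosphate accumulation, with a stated time of 90 min, in the presence of a further agent that is not named here; a lower number here means a smaller maximal response, a higher number a larger maximal response:

- compound 1, `Cc1ccc2[nH]c(C(=O)N[C@H]3CCN(S(=O)(=O)N4CCOCC4)C[C@@H]3C(=O)NCCN(C)C)cc2c1`, gives 98%
- compound 2, `Cc1ccc2[nH]c(C(=O)N[C@@H]3CCN(S(=O)(=O)c4ccccc4)C[C@@H]3C(=O)NCCN(C)C)cc2c1`, gives 93%
- compound 3, `Cc1ccc2[nH]c(C(=O)N[C@H]3CN(S(=O)(=O)c4ccccc4)C[C@@H]3C(=O)NC[C@@H]3CCCN3C)cc2c1`, gives 87%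

Compound 3 has the lowest of the three numbers. Its nearest neighbour is compound 2, whose number lies a little higher but within the usual scatter of this kind of measurement, so the two cannot be told apart. The furthest is compound 1, whose number lies higher by an amount beyond the scatter. All three, however, reach a large maximal response in this assay.

Compound 4, `Cc1ccc2[nH]c(C(=O)N[C@H]3CN(S(=O)(=O)c4ccccc4)C[C@@H]3C(=O)N[C@H]3CCCN(C)C3)cc2c1`, has not yet been measured. It is built from the same atoms as compound 3, joined differently: 1-methylpiperidin-3-yl in place of (1-methylpyrrolidin-2-yl)methyl on an amide-type nitrogen. Among the measured compounds no pair differs in only one place, so no measured step shows what such a change does to the maximal response. The change keeps the count of heavy atoms, donors and acceptors and only moves from a five-membered to a six-membered non-aromatic ring on the amide-type nitrogen. For this reason the step from compound 3 to compound 4 is expected to be small, in no clear direction and not beyond the scatter: a number 1 percentage points lower from compound 3 to compound 4 (within the scatter). Compound 4 is estimated to give 86% in this assay, with a range from 70% to 100%.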

Compound 4, largest response reached (Emax), in percent of the reference or control that the assay uses: 99%
Beside the measured number, compound 4's estimate is 13 percentage points below it; low and high end bracket the measured number.
By their numbers in this assay, from the lowest: compounds 3, 2, 1 and 4 (each within the scatter of the next, the first and the last beyond it).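

For the compounds shown here, putting 1-methylpiperidin-3-yl in place of (1-methylpyrrolidin-2-yl)methyl on the amide-type nitrogen gives, in this assay, a number 12 percentage points higher from compound 3 to compound 4 (beyond the scatter), the first comparison here in which only one place changes. It shows that the maximal response can shift with this group even though the two groups have the same heavy atoms, donors and acceptors, so those counts alone do not settle the outcome at this position. The data offer no measured explanation for the shift.

The change alters both the ring, from five-membered to six-membered, and the way the ring is joined to the amide-type nitrogen, so the compounds shown cannot separate these two features; a comparison with 1-methylpiperidin-4-yl, or with (1-methylpiperidin-2-yl)methyl, which keeps the methylene link of the old group while carrying the six-membered ring of the new one, would help to tell them apart. From the compounds shown here alone, it also remains open whether the same exchange would act alike on the core of compound 1, which carries a different group on its sulfonyl.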